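Adding an aryl group to the ring nitrogen

The source may hold more compounds than are shown below. What is called first, only, known or untested is meant among the compounds shown, and "the series" means these compounds.

compound 1 `CC(C)[C@@H]1CC[C@@H](C)C[C@@]12N(C)C(=O)[C@@H]1[C@H]3C(=O)NC(=O)[C@H]3ON12` gives 1550 ug/mL
compound 2 `CC(C)[C@@H]1CC[C@@H](C)C[C@@]12N(C)C(=O)[C@@H]1[C@H]3C(=O)N(C)C(=O)[C@H]3ON12` gives 1650 ug/mL

In a functional assay, with a stated time of 20 min (a higher number here means a weaker inhibitor, a lower number a stronger inhibitor), compound 1 and compound 2 stand level, within the scatter of each other. Compound 3 `COc1ccc(N2C(=O)[C@H]3[C@H](ON4[C@@H]3C(=O)N(C)[C@@]43C[C@H](C)CC[C@H]3C(C)C)C2=O)cc1` has not been measured yet. It differs from compound 1 in one place (in words, 4-methoxyphenyl in place of hydrogen on an amide-type nitrogen in a ring): 4-methoxyphenyl in place of hydrogen on an amide-type nitrogen in a ring and the rest of the core stays the same. Within the data shown here, the only measured step at this kind of nitrogen, methyl in place of hydrogen, is a 1.1-fold higher number from compound 1 to compound 2 (0.03 log units; within the scatter) and gives no sign of a trend. One small group is thin support for a much larger one, so the range stays wide. The expected step is a 1.0-fold lower number from compound 1 to compound 3 (0.01 log units; within the scatter) in this assay with no move beyond the scatter expected in either direction. For compound 3 the estimated value is 1500 ug/mL with an expected range from 500 ug/mL to 4000 ug/mL in this assay.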

Compound 3, half-maximal inhibitory concentration: 1120 ug/mL
Estimate against measurement, compound 3: 1.3-fold (0.13 log units) above; the measured number falls inside the stated range.
By their numbers in this assay, from the lowest: compounds 3, 1 and 2 (each within the scatter of the next).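

In this assay, the amide-type nitrogen of the shared core now carries a full 4-methoxyphenyl group, and the result is a 1.4-fold lower number from compound 1 to compound 3 (0.14 log units; within the scatter), alongside a 1.5-fold lower number from compound 2 to compound 3 (0.17 log units; within the scatter). The earlier pair showed only that a small methyl leaves the number within the scatter, whereas this shows that a much larger group with a six-membered aromatic ring does the same, so hydrogen, methyl and 4-methoxyphenyl cannot be told apart at this nitrogen in this assay. Nothing available explains why the numbers stay level.

Going by these compounds, it remains open whether any group at this nitrogen can move the number beyond the scatter. An unsubstituted phenyl ring would test the part played by the methoxy group, while a longer chain ending in an amine or a carboxylic acid would test a very different kind of group.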